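Removing Two Methyls from a Piperazine: Stability Outlook

A few compounds are considered here, and "the series" means these few. Any claim that something is new, unique, unknown or untested is made for them only; others in the source may bear on it.

Compound 2 `C[C@@H]1CN(c2cccc3c2C[C@H](CN(C)[C@H]2CCCc4cccnc42)NC3)C[C@H](C)N1` is tested in an ADME assay on microsomes from liver (Homo sapiens) for metabolic stability, read by LC-MS, with a stated time of 10 min (a lower number here means that less of the compound is left, a higher number that more of the compound is left), where compound 2 gives 100%. That is level, at the digits shown, with compound 1 `CCCN(C[C@H]1Cc2c(cccc2N2CCNCC2)CN1)[C@H]1CCCc2cccnc21`, which gives 100%; together these are the highest of the three numbers. Among the measured compounds shown here, compound 3 `CN(C[C@H]1Cc2c(cccc2N2CCN(C3COC3)CC2)CN1)[C@H]1CCCc2cccnc21` gives 83.1%, and the step of a number 16.9 percentage points lower from compound 2 to compound 3 (beyond the scatter) is the only measured change at this position. Compound 4 `CN(C[C@H]1Cc2c(cccc2N2CCNCC2)CN1)[C@H]1CCCc2cccnc21` differs from compound 2 by piperazin-1-yl in place of 3,5-dimethylpiperazin-1-yl on an aromatic carbon. The bearing step, a number 16.9 percentage points lower from compound 2 to compound 3 (beyond the scatter), swapped the same group for another piperazine and brought a modest fall. Here the outlook is steadier, because compound 1 with the plain piperazin-1-yl ring gives 100% in this assay. The expected step is therefore a number 3 percentage points lower from compound 2 to compound 4 (within the scatter), within the scatter. Compound 4 is estimated at 97%, between 85% and 100%.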

Compound 4, percent of the compound remaining: 99.7%
For compound 4 the middle estimate is 2.7 percentage points below the measured one; the range from low to high includes it.
By their numbers in this assay, from the lowest: compound 3; then compounds 4, 1 and 2 (each within the scatter of the next).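

In this assay there is a step of a number 0.3 percentage points lower from compound 2 to compound 4 (within the scatter) with piperazin-1-yl in place of 3,5-dimethylpiperazin-1-yl, so the two methyls make no readable difference at this position. Putting hydrogen in place of oxetan-3-yl on the ring amine nitrogen gives a number 16.6 percentage points higher from compound 3 to compound 4 (beyond the scatter) and ties the lower number of compound 3 to that oxetan-3-yl group. On the other amine nitrogen, the chain change gives a number 0.3 percentage points lower from compound 1 to compound 4 (within the scatter) as well. From the compounds shown here alone, whether an acetyl group or a longer chain on the ring amine nitrogen would also lower the number stays open. Nothing available explains why these numbers fall as they do.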